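Notes on a hydrazide-urea series: aryl to methyl on the core

The source may hold more compounds than are shown below. What is called first, only, known or untested is meant among the compounds shown, and "the series" means these compounds.

Measured so far:
compound 1 `Cn1nc(C(F)(F)F)c2c(-c3ccccc3)cc(NNC(=O)Nc3cc(Cl)nc(Cl)c3)nc21`, 13100 nM.
compound 3 `CCCOc1cc(NC(=O)NNc2cc(-c3ccc(OC)cc3)c3cnn(C)c3n2)cc(Cl)n1`, 37200 nM.
compound 2 `Cc1nn(C)c2nc(NNC(=O)Nc3cc(Cl)nc(Cl)c3)cc(-c3ccco3)c12`, a limit only: > 100000 nM.

All three were run in a functional assay on SW620/5-FU cells (Homo sapiens) for cytotoxicity, read by MTT assay, with a stated time of 48 h, in the presence of a further agent that is not named here; a higher number here means that more compound is needed for the effect, a lower number that less compound is needed. Compound 1 gives 13100 nM and compound 3 gives 37200 nM, both with numbers. Compound 2 reports only a limit, > 100000 nM, so no number is known for it (the limit of > 100000 nM in this assay, at which 1 of the 3 values shown sits). Within what is shown, compound 2 therefore stands at the weak end: it is the one compound of the three without a measured concentration.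

Compound 4 `Cc1cc(NNC(=O)Nc2cc(Cl)nc(Cl)c2)nc2c1c(C)nn2C` has not been measured. It differs from compound 2 by methyl in place of furan-2-yl on an aromatic carbon. Among the compounds with values here, no pair of measured compounds differs in a single place, so no measured step guides this change; compound 1 and compound 3 carry other groups at the same place but also differ elsewhere from compound 2.

The expectation for compound 4 is a weak value close to where compound 2 sits, estimated at 70000 nM with a range from 20000 nM to 200000 nM. The step expected from compound 2 to compound 4 is an at least 1.4-fold lower number from compound 2 to compound 4 (0.15 log units; that floor lies within the scatter), at most a modest move toward lower concentrations and quite possibly none beyond the scatter, with a fair chance that a limit is again reported.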

Compound 4, half-maximal effective concentration: > 100000 nM
Compound 4: no number, only a limit; the forecaster's own chance of this, stated with the estimate: 50%; at least 1.4-fold (0.15 log units) between middle value and limit.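

Compound 4, like compound 2, returns only a limit, so no step can be read for methyl in place of furan-2-yl on the shared core: the limit of > 100000 nM in this assay, at which 2 of the 4 values shown sit.

The compounds shown leave open whether this change moves the concentration needed at all, and where compound 2 and compound 4 would sit relative to each other.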